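A few compounds are considered here, and "the series" means these few. Any claim that something is new, unique, unknown or untested is made for them only; others in the source may bear on it.

Compound 1, `NCCNc1cc(N2CCN(c3cccc(Cl)c3)CC2)nc2ccccc12`, carries a 3-chlorophenyl group on the ring nitrogen of its piperazine-like ring. In an ADME assay on HEp-2 cells (Homo sapiens) for cytotoxicity, read by CCK-8 assay, with a stated time of 6 days (on this read-out lower numbers stand for higher toxicity in this test and higher numbers for lower toxicity in this test), compound 1 gives 6400 nM. Compound 2, `CS(=O)(=O)N1CCN(c2cc(NCCN)c3ccccc3n2)CC1`, bears a methylsulfonyl group at that same position. In this assay compound 2 gives only a limit, > 100000 nM, not a number. For the measured compounds named here, the single measured step, an at least 15-fold higher number from compound 1 to compound 2 (1.19 log units; beyond the scatter), therefore sits partly on (the limit of > 100000 nM in this assay, at which 1 of the 2 values shown sits), so the true size of that step is not known, only that it is large. Compound 2 thus stands at the least toxic end of what has been measured, with its value known only as a limit.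

Compound 3, `NCCNc1cc(N2CCN(c3ccccc3Cl)CC2)nc2ccccc12`, differs from compound 2 by 2-chlorophenyl in place of methylsulfonyl on an amine nitrogen in a ring. This change reverses the kind of swap seen in the measured step from compound 1 to compound 2, replacing the methylsulfonyl with a chlorophenyl group again, so the step is expected to run back toward higher toxicity. The expected step is an at least 14-fold lower number from compound 2 to compound 3 (1.15 log units; beyond the scatter). Compound 3 is therefore estimated at 7000 nM in this assay, with a range from 2500 nM to 25000 nM.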

Compound 3, half-maximal cytotoxic concentration: 20800 nM
The estimate for compound 3 lay 3.0-fold (0.47 log units) below the measured number; the measured number falls inside the stated range.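

In this assay, exchanging 3-chlorophenyl for 2-chlorophenyl on the ring nitrogen gives a 3.3-fold higher number from compound 1 to compound 3 (0.51 log units; beyond the scatter), so at this position the result depends on where the chlorine sits on the phenyl ring, not only on whether a chlorophenyl group is present. Going from methylsulfonyl to 2-chlorophenyl at the same position gives an at least 4.8-fold lower number from compound 2 to compound 3 (0.68 log units; beyond the scatter), so both chlorophenyl compounds read as more toxic in this test than the methylsulfonyl compound, though to different degrees. The size of that second step is only a lower bound, since compound 2 has a limit and not a number: the limit of > 100000 nM in this assay, at which 1 of the 3 values shown sits.

The compounds shown leave open how a plain phenyl group with no chlorine would read on this ring nitrogen, and so how much of the gap to methylsulfonyl goes with the aromatic ring and how much with the chlorine. They also leave open whether a different group without an aromatic ring, such as acetyl, would read as low in toxicity as methylsulfonyl does.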